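This account rests on a few compounds, and the source may have more. Where it says the series, first, only, none or still open, it means among the compounds named here.

Of the compounds shown here, two built on a shared core have been tested in a functional assay on HeLa cells (Homo sapiens) for antiproliferative activity, read by MTT assay, with a stated time of 48 h; a lower number here means a stronger inhibitor, a higher number a weaker inhibitor. Compound 1 `Cc1ccc(-c2nc3ccc(Cl)cc3c(=S)[nH]2)cc1` gives 4.57 ug/mL in this assay. Compound 2 `Cc1ccc(-c2nc(NO)c3cc(Cl)ccc3n2)cc1` gives 12.7 ug/mL in this assay, which is the higher of the two numbers, so compound 2 is the weaker inhibitor of the pair, and the gap to compound 1 lies beyond the usual scatter. Going by the values given here, the two compounds differ in more than one place, so their two values show only that compound 1 is the stronger of them, not which part of the structure accounts for it.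

Compound 3 `Cc1ccc(-c2nc(NC(=O)c3ccccc3)c3cc(Cl)ccc3n2)cc1` differs from compound 2 in a single place: benzoyl in place of hydroxy on a nitrogen on an aromatic ring. Among the compounds with values here, no measured pair in this set shows the same exchange, so nothing here tells which way the number will move. Within the data shown here, with no comparable step to lean on, the step from compound 2 to compound 3 is expected to be modest, a 1.3-fold lower number from compound 2 to compound 3 (0.10 log units; within the scatter), in either direction or none beyond the scatter. Compound 3 is therefore estimated to give 10 ug/mL in this assay, within a range from 3 ug/mL to 30 ug/mL.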

Compound 3, half-maximal inhibitory concentration: 16.2 ug/mL
For compound 3 the middle estimate is 1.6-fold (0.21 log units) below the measured one; the range from low to high includes it.
By their numbers in this assay, from the lowest: compound 1; then compounds 2 and 3 (each within the scatter of the next).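

In this assay, putting benzoyl in place of hydroxy on a nitrogen on an aromatic ring, which turns hydroxyamino into benzamido, gives a 1.3-fold higher number from compound 2 to compound 3 (0.11 log units; within the scatter) and so stays within the usual scatter of repeat measurements. Going by these compounds alone, this is the first view of this position, and it shows that a group of 8 heavy atoms with a six-membered aromatic ring and no hydrogen-bond donor can replace a hydroxy of 1 heavy atom with a hydrogen-bond donor, without a change in the number that can be told from scatter. Nothing measured here explains why so large an exchange leaves the number within the scatter.

One exchange on this nitrogen does not show what a smaller acetyl group, a plain amine or a benzoyl with a methoxy group on its ring would do. On these data alone, compound 1 differs from compound 2 and compound 3 in more than one place, so which part of its structure goes with its lower number also stays open.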